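Trifluoromethyl to Methoxy: Expected Effect on Inhibition

A few compounds are considered here, and "the series" means these few. Any claim that something is new, unique, unknown or untested is made for them only; others in the source may bear on it.

Of the compounds shown here, two sharing one core have been tested in a functional assay on the whole organism with Mus musculus as the target, with a stated time of 1 h, at a dose of 100 mg/kg by the intraperitoneal route; on this read-out lower numbers stand for less inhibition and higher numbers for more inhibition at the one dose given (going by the name of the read-out). Compound 1 `FC(F)(F)c1ccc(COc2nc3ccccc3s2)cc1` gives 12.2% in this assay, the highest of the two numbers. Compound 2 `Cc1cc(C)cc(COc2nc3ccccc3s2)c1` gives 0.5% in this assay, a number lower than that of compound 1 by more than the usual scatter. Going by the values given here, no two measured compounds differ in only one place, so nothing can yet be said about how a single change moves this read-out.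

Compound 3 `COc1ccc(COc2nc3ccccc3s2)cc1` has not been measured. It differs from compound 1 in one respect: methoxy in place of trifluoromethyl on an aromatic carbon. The group that leaves and the group that enters sit on the same aromatic carbon, and nothing else in the molecule changes. Because compound 1 gives only 12.2% and compound 2 gives 0.5%, compound 3 is expected to give 5% in this assay, with a range from 0% to 20%. The expected step of a number 7.2 percentage points lower from compound 1 to compound 3 (within the scatter) is therefore small, downward if anything, and most likely not beyond the scatter.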

Compound 3, a percentage reported as inhibition, in the whole organism at one dose (the size of the read-out at that dose, not a potency): 2.43%
The estimate for compound 3 lay 2.6 percentage points above the measured number; measured number inside the range.
By their numbers in this assay, from the lowest: compounds 2, 3 and 1 (each within the scatter of the next, the first and the last beyond it).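

In this assay, going by these compounds alone, methoxy in place of trifluoromethyl on an aromatic carbon, para to a large group, gives a number 9.8 percentage points lower from compound 1 to compound 3 (within the scatter), and this is the first single change that can be read directly. At the one dose tested, this read-out therefore does not separate these two groups at this position, even though the leaving group has 4 heavy atoms and 0 hydrogen-bond acceptors, while the entering group has 2 heavy atoms and 1 hydrogen-bond acceptor. Nothing among the data shown bears on why the two compounds cannot be told apart here.

From the compounds shown here alone, it remains open whether an amine, a carboxylic acid or a longer chain such as ethoxy on this aromatic carbon would give a number beyond the scatter from that of compound 1. Going by these compounds, it is also open whether trifluoromethyl and methoxy would still read alike at another dose or at another time after dosing, or if either group were placed on a different carbon of the same ring.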